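This account rests on a few compounds, and the source may have more. Where it says the series, first, only, none or still open, it means among the compounds named here.

The measured compounds:

Compound 1, `CC1=NN(C(=O)COc2ccc(Cl)cc2)C(c2ccccc2O)C1` — 38800 nM in a functional assay on PC-3 cells (Homo sapiens) for cytotoxicity, read by MTT assay, with a stated time of 48 h; a lower number here means a stronger inhibitor, a higher number a weaker inhibitor
Compound 2, `CCC(=O)N1N=C(C)CC1c1cc(Br)ccc1O` — 37800 nM in this assay
Compound 3, `CCC(=O)N1N=C(C)CC1c1cc(Br)cc(Br)c1O` — 28600 nM in this assay

Compound 3 gives the lowest of the three numbers in this assay, but its gap to compound 2 is within the scatter, as is its gap to compound 1, so nothing separates the three beyond the usual spread. Among the compounds with values here, the one single-point step among them, a 1.3-fold lower number from compound 2 to compound 3 (0.12 log units; within the scatter), is a bromo in place of hydrogen on an aromatic carbon and changes little.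

Compound 4, `CC1=NN(C(=O)COc2ccc(Cl)cc2)C(c2cc(Br)cc(Br)c2O)C1`, is not yet measured. It comes from compound 3 by 4-chlorophenoxy in place of methyl on a saturated chain carbon bound to a carbonyl carbon. Within the data shown here, no measured step carries exactly this change. Compound 1 already bears the 4-chlorophenoxy on the same carbon, without the two bromines, and its value in this assay sits within the scatter of compound 3, while the two bromines themselves, judged from a 1.3-fold lower number from compound 2 to compound 3 (0.12 log units; within the scatter), also left the number essentially unchanged. Compound 4 is therefore expected to land close to compound 3, with a 1.1-fold higher number from compound 3 to compound 4 (0.03 log units; within the scatter) as the estimated step, and no movement beyond the scatter in either direction. The estimate for compound 4 in this assay is 31000 nM, from 15000 nM to 65000 nM.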

Compound 4, half-maximal inhibitory concentration: 40200 nM
For compound 4 the middle estimate is 1.3-fold (0.11 log units) below the measured one; measured number inside the range.
By their numbers in this assay, from the lowest: compounds 3, 2, 1 and 4 (each within the scatter of the next).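

In this assay, the change on the saturated chain carbon bound to a carbonyl carbon now has a direct reading: a 1.4-fold higher number from compound 3 to compound 4 (0.15 log units; within the scatter). With the two bromines held constant on the shared core, a single methyl and a 4-chlorophenoxy with its eight heavy atoms, six-membered aromatic ring and hydrogen-bond acceptor therefore give numbers that cannot be told apart, so this position accepts a much larger group with no readable effect on the result in this cell assay. No measurement shown explains this result, and the step carries no information about its cause.

Every single-place step among the compounds shown lies within the scatter, so it remains open whether any change at this position can move the number beyond it, for instance an amine or a carboxylic acid on that carbon, or a longer chain in place of the methyl. Also open, on these data alone, is what a methoxy in place of the hydroxyl on the aromatic ring would do, as that group stays the same throughout these compounds.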